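Ether substituent swap on the compound 3 scaffold

The source may hold more compounds than are shown below. What is called first, only, known or untested is meant among the compounds shown, and "the series" means these compounds.

For the measured compounds named here, compound 3 `Cc1n[nH]c2nc(-c3ccc(NS(=O)(=O)c4cc(Cl)ccc4F)cc3)nc(OCC3(CN)COC3)c12` gives the lowest number of the three compounds so far in an assay for inhibition of serine/threonine-protein kinase Sgk1 (Homo sapiens), with stated times of 30 min and 60 min, in the presence of a further agent that is not named here (on this read-out higher numbers stand for weaker inhibition and lower numbers for stronger inhibition), at 1 nM. Compound 2 `CN1CCC(CNC(=O)c2cc(-c3ccc(NS(=O)(=O)c4cccc(Cl)c4Cl)cc3)nc3[nH]ncc23)C1` gives 45 nM in this assay, and compound 1 `CC(C)NC(=O)c1cc(-c2ccc(NS(=O)(=O)c3cccc(Cl)c3Cl)cc2)nc2[nH]ncc12` gives 17600 nM; compound 3 sits beyond the scatter from both of them.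

Compound 4 `Cc1n[nH]c2nc(-c3ccc(NS(=O)(=O)c4cc(Cl)ccc4F)cc3)nc(OC3CC(C)(C)NC(C)(C)C3)c12` is not yet measured. It differs from compound 3 in one place: 2,2,6,6-tetramethylpiperidin-4-yl in place of (3-(aminomethyl)oxetan-3-yl)methyl on an oxygen on an aromatic ring. The aminomethyl on the oxetane is given up, and the ring nitrogen of the entering group becomes the sole donor.

Going by the values given here, only one measured step is available for comparison, and it sits elsewhere on the molecule, on an amide-type nitrogen rather than on an ether oxygen: a 390-fold lower number from compound 1 to compound 2 (2.59 log units; beyond the scatter). That step shows that exchanging a small alkyl for a saturated amine-containing ring can move this assay a great deal, but compound 3 already carries an amine and a small ring, so the present change is an exchange between two amine-bearing groups rather than an introduction of one. Among the compounds with values here, a step beyond the scatter is therefore possible in either direction, and no measured pair points to its sign.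

The working expectation for compound 4 is a number close to that of compound 3, estimated at 3 nM with a range of 0.6 nM to 20 nM, which would mean an expected step of a 3.0-fold higher number from compound 3 to compound 4 (0.48 log units; beyond the scatter).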

Compound 4, half-maximal inhibitory concentration: 4 nM
Estimate against measurement, compound 4: 1.3-fold (0.12 log units) below; the measured number falls inside the stated range.
By their numbers in this assay, from the lowest: compound 3; then compound 4; then compound 2; then compound 1.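

For the compounds shown here, exchanging (3-(aminomethyl)oxetan-3-yl)methyl for 2,2,6,6-tetramethylpiperidin-4-yl on the oxygen gives a 4.0-fold higher number from compound 3 to compound 4 (0.60 log units; beyond the scatter) in this assay and is the first measured change at this position. The step is beyond the scatter but modest, so this position accepts a larger group with a six-membered ring in place of the four-membered one, at a limited loss in this read-out. Both groups carry one nitrogen and one hydrogen-bond donor, so the pair shows that the aminomethyl on the oxetane can be given up when a ring nitrogen is present, but it does not separate the roles of ring size, group size and nitrogen placement. No measured evidence on the cause of this step is available here.

On these data alone, it remains open whether a nitrogen is needed on this oxygen at all, which a cyclohexyl group or a short chain ending in a hydroxyl would test. As far as these compounds go, it is also open what the four methyl groups contribute, which the unsubstituted piperidin-4-yl group would show.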